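Swapping the Ester Tail for a Branched Alcohol

The source may hold more compounds than are shown below. What is called first, only, known or untested is meant among the compounds shown, and "the series" means these compounds.

Three compounds share one core and have been measured in a functional assay on PC-3 cells (Homo sapiens) for antiproliferative activity, read by MTT assay, with a stated time of 24 h; on this read-out lower numbers stand for stronger inhibition and higher numbers for weaker inhibition:

Compound 1 `CCn1c(C(=O)NCCC(=O)OC)ccc1C(CC)(CC)c1ccc(OCS(=O)(=O)c2ccccc2)c(C)c1` gives 40400 nM
Compound 2 `CCn1c(C(=O)NCCN)ccc1C(CC)(CC)c1ccc(OCS(=O)(=O)c2ccccc2)c(C)c1` gives 6890 nM
Compound 3 `CCn1c(C(=O)NCCO)ccc1C(CC)(CC)c1ccc(OCS(=O)(=O)c2ccccc2)c(C)c1` gives 17700 nM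

Compound 1 stands highest of the three, so it is the weakest inhibitor among them. Compound 4 `CCn1c(C(=O)N[C@@H](CO)C(C)C)ccc1C(CC)(CC)c1ccc(OCS(=O)(=O)c2ccccc2)c(C)c1` differs from compound 1 in one place: 1-(hydroxymethyl)-2-methylpropyl in place of 2-(methoxycarbonyl)ethyl on an amide-type nitrogen. For the measured compounds named here, two measured steps bear on this, as both also remove the methoxycarbonyl group from the chain: a 5.9-fold lower number from compound 1 to compound 2 (0.77 log units; beyond the scatter) and a 2.3-fold lower number from compound 1 to compound 3 (0.36 log units; beyond the scatter). Going by the values given here, the new group in compound 4 carries a hydroxy, as in compound 3, plus branching that no measured pair tests. A modest lowering is therefore expected, a 2.5-fold lower number from compound 1 to compound 4 (0.40 log units; beyond the scatter). Compound 4 is estimated at 16000 nM, within a range from 6000 nM to 40000 nM.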

Compound 4, half-maximal inhibitory concentration: 10600 nM
Beside the measured number, compound 4's estimate is 1.5-fold (0.18 log units) above it, within the range that was stated.
By their numbers in this assay, from the lowest: compounds 2, 4 and 3 (each within the scatter of the next, the first and the last beyond it); then compound 1.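

In this assay the change brings a 3.8-fold lower number from compound 1 to compound 4 (0.58 log units; beyond the scatter) as the branched alcohol 1-(hydroxymethyl)-2-methylpropyl replaces the ester chain on the amide-type nitrogen, so this position tolerates branching. Adding isopropyl to the chain of compound 3 gives a 1.7-fold lower number from compound 3 to compound 4 (0.22 log units; within the scatter) and swapping 2-aminoethyl for the branched alcohol gives a 1.5-fold higher number from compound 2 to compound 4 (0.19 log units; within the scatter) so branching neither clearly helps nor harms here. Nothing available explains these numbers.

Still open, going by these compounds, is how the opposite stereocentre would behave, and whether a carboxylic acid or a longer chain would keep this level of activity.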